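The source may report more compounds than this note shows. Statements on the series, on what has been measured and on what is new or still open speak of the compounds shown alone.

Of the compounds shown here, three sharing one core have been measured in a functional assay (brain) for displacement of a labelled ligand, with Rattus norvegicus as the target; a higher number here means a weaker inhibitor, a lower number a stronger inhibitor. Compound 1 `CCN1CCCC[C@H]1[C@H]1COC(c2ccccc2)(c2ccccc2)O1` gives 6900 nM, compound 2 `C[C@H](N)[C@H]1COC(c2ccccc2)(c2ccccc2)O1` gives 607 nM, and compound 3 `CCC[C@H](NC)[C@H]1COC(c2ccccc2)(c2ccccc2)O1` gives 7000 nM. Compound 3 has the highest of the three numbers, though one neighbouring step, a 1.0-fold higher number from compound 1 to compound 3 (0.01 log units; within the scatter), is too small to count, while the other, a 12-fold higher number from compound 2 to compound 3 (1.06 log units; beyond the scatter), is a large rise. Compound 4 `c1ccc(C2(c3ccccc3)OC[C@H]([C@@H]3CCCN3)O2)cc1` has not yet been measured; the change is pyrrolidin-2-yl in place of 1-(methylamino)butyl on a saturated ring carbon. Both earlier steps bear on it: compound 2 shows that a change at this carbon can move the number a great deal, whereas the ring of compound 1 brought no shift against compound 3. Because a 12-fold higher number from compound 2 to compound 3 (1.06 log units; beyond the scatter) ran upward as the group grew, the reverse direction is expected here, with the estimated step being a 4.7-fold lower number from compound 3 to compound 4 (0.67 log units; beyond the scatter). Compound 4 is thus expected to give about 1500 nM, in a range from 400 nM to 5500 nM.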

Compound 4, inhibition constant: > 10000 nM
Compound 4 was reported as a limit; the forecaster's own chance of this, stated with the estimate: 5%; at least 6.6-fold (0.82 log units) between middle value and limit.
By their numbers in this assay, from the lowest: compound 2; then compounds 1 and 3 (each within the scatter of the next). At a limit, above all of these: compound 4.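

Compound 4 is reported only as a limit of the assay, not as a number: the limit of > 10000 nM in this assay, at which 1 of the 4 values shown sits. With an at least 16-fold higher number from compound 2 to compound 4 (1.21 log units; beyond the scatter) as a large step, the pyrrolidin-2-yl group does not bring back the low number seen with the 1-aminoethyl group. Having fewer heavy atoms than 1-(methylamino)butyl therefore did not by itself lower the number at this saturated ring carbon.

The steps of an at least 1.4-fold higher number from compound 3 to compound 4 (0.15 log units; that floor lies within the scatter) and an at least 1.4-fold higher number from compound 1 to compound 4 (0.16 log units; that floor lies within the scatter) cannot be read, as their floors lie within the scatter. Also open, on these data alone, is whether an aminomethyl group or an unsubstituted piperidin-2-yl ring would keep the low number of compound 2.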